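A few compounds are considered here, and "the series" means these few. Any claim that something is new, unique, unknown or untested is made for them only; others in the source may bear on it.

Measured so far in a functional assay on HUVEC cells (Homo sapiens); a lower number here means that less compound is needed, a higher number that more compound is needed for the effect:
- compound 1 `COC1=C(C)C(=O)/C(=C(O)/C=C/c2ccccc2OC)C(=O)C1(C)C`, a limit: < 4 ug/mL
- compound 2 `COC1=C(C)C(=O)/C(=C(O)/C=C/c2ccc(F)cc2)C(=O)C1(C)C`, a limit: < 4 ug/mL
- compound 3 `C=Cc1ccccc1/C=C/C(O)=C1/C(=O)C(C)=C(OC)C(C)(C)C1=O`, a limit: < 1.1 ug/mL

Compound 1 stands only at a limit in this assay, and the two further values shown are limits as well (the limit of < 4 ug/mL in this assay, at which 2 of the 3 values shown sit), (the limit of < 1.1 ug/mL in this assay, at which 1 of the 3 values shown sits). The measured steps are therefore unreadable: a step that the two limits leave unreadable from compound 1 to compound 2, a step that the two limits leave unreadable from compound 1 to compound 3 and a step that the two limits leave unreadable from compound 2 to compound 3. Compound 4 `COC1=C(C)C(=O)/C(=C(O)/C=C/c2cccs2)C(=O)C1(C)C` differs from compound 1 as follows: thiophen-2-yl in place of 2-methoxyphenyl on a double-bonded chain carbon bound to a double-bonded chain carbon. Within the data shown here, no measured step with a readable size bears on this change, so no step beyond the scatter is expected in this assay; the value of compound 4 is expected to land near the limits seen. Compound 4 is estimated at 2 ug/mL, within 0.5 ug/mL to 6 ug/mL, an expected step that the limit leaves unreadable from compound 1 to compound 4.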

Compound 4, concentration for half-maximal effect: < 4 ug/mL
Compound 4: no number, only a limit (the forecaster's own chance of this, stated with the estimate: 60%); the middle value lies beyond the limit too.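

In this assay compound 4 gives < 4 ug/mL, a limit. Its steps to compound 1, compound 2 and compound 3 cannot be read. The compounds shown leave open whether thiophen-2-yl, 2-methoxyphenyl, 4-fluorophenyl and 2-vinylphenyl differ at all in this assay.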